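Trimethoxyphenyl pyrazole chalcones: predicting a further methoxy step

The compounds below may be only part of what the source reports. "The series", "measured", "known", "first", "only" and "open" are said of these compounds alone.

Measured compounds:
compound 1, `COc1cc(-c2cc(/C=C/C(=O)c3ccc(N)cc3)[nH]n2)cc(OC)c1OC`, 5100 nM
compound 2, `COc1ccc(C(=O)/C=C/c2cc(-c3cc(OC)c(OC)c(OC)c3)n[nH]2)cc1OC`, 3330 nM
compound 3, `COc1ccc(-c2cc(/C=C/C(=O)c3ccc(N)cc3)[nH]n2)cc1OC`, 4530 nM

Three pyrazole-linked enones have been tested in a functional assay on NCI-H460 cells (Homo sapiens) for inhibition, read by sulforhodamine B assay, with a stated time of 48 h; a higher number here means a weaker inhibitor of growth, a lower number a stronger inhibitor of growth. Compound 3 gives 4530 nM, and compound 1 gives 5100 nM. Compound 2 gives 3330 nM. The three values all lie within the usual scatter of one another, so none can be ranked against the others.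

The change from compound 3 to compound 1 is methoxy in place of hydrogen on an aromatic carbon, and it produced a 1.1-fold higher number from compound 3 to compound 1 (0.05 log units; within the scatter). Compound 1 and compound 2 differ by a 1.5-fold lower number from compound 1 to compound 2 (0.19 log units; within the scatter). The difference between the cores of compound 2 and compound 3 is not broken down here.

Compound 4, `COc1cc(C(=O)/C=C/c2cc(-c3cc(OC)c(OC)c(OC)c3)n[nH]2)cc(OC)c1OC`, has not yet been measured. It arises from compound 2 through (methoxy in place of hydrogen on an aromatic carbon), the same change as that from compound 3 to compound 1. Because that earlier step was a 1.1-fold higher number from compound 3 to compound 1 (0.05 log units; within the scatter), compound 4 is expected to sit close to compound 2, with an estimated step of a 1.1-fold higher number from compound 2 to compound 4 (0.05 log units; within the scatter) in this assay. This rests on a single precedent, so the expectation is broad. Compound 4 is therefore estimated at 3700 nM, with a likely range from 1600 nM to 8500 nM.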

Compound 4, concentration for total growth inhibition: 4330 nM
Beside the measured number, compound 4's estimate is 1.2-fold (0.07 log units) below it, within the range that was stated.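

In this assay, methoxy in place of hydrogen on an aromatic carbon gives a 1.3-fold higher number from compound 2 to compound 4 (0.11 log units; within the scatter), and the two available cases of this change agree within the scatter: the same change on two cores in this assay, a 1.1-fold higher number (0.05 log units; within the scatter) from compound 3 to compound 1 and a 1.3-fold higher number (0.11 log units; within the scatter) from compound 2 to compound 4, 1.2-fold (0.06 log units) apart, within the scatter of two such steps. On these two cores, then, the change carries over in the limited sense that neither step can be told from the scatter, even though it adds the methoxy to a different aromatic ring in each case. This does not show that the change has a real direction or a fixed size, and two cores are too few to say that it would stay this small on any other core in the series.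

The compounds shown leave open whether a hydroxyl or ethoxy group in place of one of these methoxy groups would give a step beyond the scatter in this assay. They also leave open whether a carboxylic acid in place of the amine on the core of compound 1 would move the number further than any of the changes seen so far.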